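This account rests on a few compounds, and the source may have more. Where it says the series, first, only, none or still open, it means among the compounds named here.

Measured compounds:
- compound 1 `CN(C)CCCNc1nc(-c2ccc(NC(=O)Nc3ccc(F)cc3)cc2)nc2c(Cl)c(Cl)sc12`: 1120 nM
- compound 2 `CN(C)CCCNc1nc(-c2ccc(NC(=O)Nc3ccc(Cl)cc3)cc2)nc2c(Cl)c(Cl)sc12`: 1530 nM
- compound 3 `CN(C)CCNc1nc(-c2ccc(NC(=O)Nc3ccc(F)cc3)cc2)nc2c(Cl)c(Cl)sc12`: 1350 nM

All three were tested in a functional assay on MKN-45 cells (Homo sapiens) for cytotoxicity, read by MTT assay, with a stated time of 72 h; a higher number here means a weaker inhibitor, a lower number a stronger inhibitor. Compound 3 gives 1350 nM, the second highest of the three numbers; the gap to compound 2 and the gap to compound 1 both lie within the scatter, so the three compounds cannot be told apart on these numbers.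

Compound 4 `CN(C)CCNc1nc(-c2ccc(NC(=O)Nc3ccc(Cl)cc3)cc2)nc2c(Cl)c(Cl)sc12` has not yet been measured. It differs from compound 3 in a single place: chloro in place of fluoro on an aromatic carbon. The same exchange has already been made once within this set, on the pair that carries the longer chain: the step of a 1.4-fold higher number from compound 1 to compound 2 (0.14 log units; within the scatter) was within the scatter. Compound 1 and compound 3 differ in the chain, and the step of a 1.2-fold higher number from compound 1 to compound 3 (0.08 log units; within the scatter) was also within the scatter, so the chain does not seem to alter what the halogen exchange does.

The expectation for compound 4 in this assay is therefore a step of a 1.3-fold higher number from compound 3 to compound 4 (0.10 log units; within the scatter), at most a slightly higher number and quite possibly no change beyond the scatter. Compound 4 is estimated at 1700 nM, with a range from 900 nM to 3200 nM.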

Compound 4, half-maximal inhibitory concentration: 910 nM
Compound 4: middle estimate off by 1.9-fold (0.27 log units), on the high side; the measured number falls inside the stated range.
By their numbers in this assay, from the lowest: compounds 4, 1, 3 and 2 (each within the scatter of the next).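

In this assay, the change from 4-fluorophenyl to 4-chlorophenyl now has a second reading, on the chain of compound 3, and that step is a 1.5-fold lower number from compound 3 to compound 4 (0.17 log units; within the scatter). Set beside the first reading, it shows no consistent direction for this exchange, and the two readings cannot be told apart: the same change on two cores in this assay, a 1.4-fold higher number (0.14 log units; within the scatter) from compound 1 to compound 2 and a 1.5-fold lower number (0.17 log units; within the scatter) from compound 3 to compound 4, 2.0-fold (0.31 log units) apart, within the scatter of two such steps. For the compounds shown here, the chain change, read for the first time with 4-chlorophenyl in place, is a 1.7-fold lower number from compound 2 to compound 4 (0.23 log units; within the scatter), so it too stays small on either halogen and the two readings again cannot be told apart: the same change on two cores in this assay, a 1.2-fold higher number (0.08 log units; within the scatter) from compound 1 to compound 3 and a 1.7-fold lower number (0.23 log units; within the scatter) from compound 2 to compound 4, 2.0-fold (0.31 log units) apart, within the scatter of two such steps.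

All the steps among these compounds lie within the scatter, so neither the halogen nor the chain has yet been shown to matter in this assay. From the compounds shown here alone, whether this position responds at all remains open, and would take a group further from the two halogens, such as methoxy or a carboxylic acid in place of the chloro, or a much longer chain ending in a morpholine ring in place of the dimethylamino chain.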